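The compounds below may be only part of what the source reports. "The series", "measured", "known", "first", "only" and "open" are said of these compounds alone.

Among the measured compounds shown here, in a functional assay on MDA-MB-231 cells (Homo sapiens) for cytotoxicity, read by MTT assay, with a stated time of 72 h (on this read-out lower numbers stand for stronger inhibition and higher numbers for weaker inhibition), three compounds with a shared core have numbers so far: compound 1 `O=C1c2c[n+]([O-])c3ccccc3c2C(=O)c2c1c1ccccc1n2Cc1cn([C@H]2O[C@H](CO)[C@@H](O)[C@H]2O)nn1` gives 1700 nM, compound 2 `O=C1c2c[n+]([O-])c3ccccc3c2C(=O)c2c1c1ccccc1n2CCN1CCCC1` gives 630 nM and compound 3 `O=C1c2c[n+]([O-])c3ccccc3c2C(=O)c2c1c1ccccc1n2CCCCN1CCNCC1` gives 3310 nM. Compound 3 thus lies within the scatter of compound 1 and clearly above compound 2. Compound 4 `CN(C)CCCCn1c2c(c3ccccc31)C(=O)c1c[n+]([O-])c3ccccc3c1C2=O` differs from compound 3 in one place: dimethylamino in place of piperazin-1-yl on a saturated chain carbon, four bonds along the chain from an aromatic nitrogen. For the measured compounds named here, only one measured step bears on this, a 5.3-fold higher number from compound 2 to compound 3 (0.72 log units; beyond the scatter), a modest step that also changes the group at the end of the chain. It is a hint, not a rule. A modest move towards a lower number is expected, estimated as a 2.4-fold lower number from compound 3 to compound 4 (0.37 log units; beyond the scatter) in this assay. For compound 4 the estimated value is 1400 nM, with an expected range of 450 nM to 4000 nM.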

Compound 4, half-maximal inhibitory concentration: 350 nM
Compound 4: the middle estimate sits 4.0-fold (0.60 log units) above what was measured; the whole stated range lies above it.
By their numbers in this assay, from the lowest: compounds 4 and 2 (each within the scatter of the next); then compounds 1 and 3 (each within the scatter of the next).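

In this assay dimethylamino in place of piperazin-1-yl gives a 9.5-fold lower number from compound 3 to compound 4 (0.98 log units; beyond the scatter) with the chain left as it is, so the end group alone can move this number well beyond the scatter. The other new step, a 1.8-fold lower number from compound 2 to compound 4 (0.26 log units; within the scatter), lies within the scatter, so those two compounds cannot be told apart here. Nothing measured here says why the numbers differ.

Still open, on these data alone, is whether diethylamino or morpholin-4-yl at the same chain end would behave like dimethylamino or like piperazin-1-yl. Also open, as far as these compounds go, is how dimethylamino would fare on a shorter chain.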